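From pyrimidin-5-yl to 2-ethoxypyridin-3-yl on the shared core

A few compounds are considered here, and "the series" means these few. Any claim that something is new, unique, unknown or untested is made for them only; others in the source may bear on it.

Of the compounds shown here, three sharing one core have been measured in a functional assay on BJAB cells (Homo sapiens) for antiproliferative activity, with a stated time of 4 days; on this read-out lower numbers stand for an effect already at smaller amounts and higher numbers for an effect only at larger amounts of compound. Compound 1 `COc1ccc(C)cc1-c1c(C)nn(-c2nc(-c3ccc(Cl)c(Cl)c3)c(SC(C)C)s2)c1C(=O)O` gives 9500 nM, compound 2 `Cc1ccccc1-c1c(C)nn(-c2nc(-c3ccc(Cl)c(Cl)c3)c(SC(C)C)s2)c1C(=O)O` gives 5500 nM, and compound 3 `Cc1nn(-c2nc(-c3ccc(Cl)c(Cl)c3)c(SC(C)C)s2)c(C(=O)O)c1-c1cncnc1` gives 22000 nM. Compound 3 thus stands at the highest number of the three: the step of a 2.3-fold higher number from compound 1 to compound 3 (0.36 log units; beyond the scatter) and the step of a 4.0-fold higher number from compound 2 to compound 3 (0.60 log units; beyond the scatter) both lie beyond the scatter, while the step of a 1.7-fold lower number from compound 1 to compound 2 (0.24 log units; within the scatter) does not.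

The next compound, compound 4 `CCOc1ncccc1-c1c(C)nn(-c2nc(-c3ccc(Cl)c(Cl)c3)c(SC(C)C)s2)c1C(=O)O`, changes the same position again: 2-ethoxypyridin-3-yl in place of pyrimidin-5-yl on an aromatic carbon. The two steps that lead into compound 3 bear on this move. Both replaced a six-membered ring bearing a methyl or methoxy group with pyrimidin-5-yl, and both raised the number modestly. Compound 4 moves back toward such rings, since 2-ethoxypyridin-3-yl carries one hetero atom and an ethoxy group, recalling the 2-methoxy-5-methylphenyl of compound 1 with its 9500 nM. A modest lowering in this assay is therefore expected, of about a 2.8-fold lower number from compound 3 to compound 4 (0.44 log units; beyond the scatter). For compound 4 the estimate in this assay is 8000 nM, with a likely range from 3000 nM to 25000 nM.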

Compound 4, half-maximal effective concentration: 11000 nM
For compound 4 the middle estimate is 1.4-fold (0.14 log units) below the measured one; low and high end bracket the measured number.
By their numbers in this assay, from the lowest: compounds 2, 1, 4 and 3 (each within the scatter of the next, the first and the last beyond it).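

In this assay, putting 2-ethoxypyridin-3-yl in place of pyrimidin-5-yl gives a 2.0-fold lower number from compound 3 to compound 4 (0.30 log units; within the scatter), so this larger group, with its ethoxy chain and a single ring nitrogen, produces no change that can be told from the usual scatter. Compound 4 also cannot be separated from the two compounds with substituted phenyl rings, with a 2.0-fold higher number from compound 2 to compound 4 (0.30 log units; within the scatter) and a 1.2-fold higher number from compound 1 to compound 4 (0.06 log units; within the scatter), even though compound 2 and compound 3 do differ beyond the scatter; it therefore sits in the gap between them and joins neither side, showing that the earlier spread at this position does not divide these rings into two clear groups. No supporting measurement is available to explain how these groups act at this position.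

The compounds shown leave open whether the ethoxy group or the ring nitrogen matters more, as no pair here changes one without the other. Going by these compounds, every group at this position is a six-membered aromatic ring, so how an amine or a longer open chain would behave on this aromatic carbon also remains open.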